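This account rests on a few compounds, and the source may have more. Where it says the series, first, only, none or still open, it means among the compounds named here.

Compound 1 `CCCn1c(=O)c2nc([C@H]3CC4C=CC3C4)[nH]c2n(CCC)c1=O` gives 3.4 nM in an assay on cell membranes for binding affinity to adenosine receptor A1 (Cavia porcellus), read by radioligand binding; on this read-out lower numbers stand for stronger inhibition and higher numbers for weaker inhibition. Compound 2 `CCCn1c(=O)c2nc(-c3cc4ccccc4s3)[nH]c2n(CCC)c1=O` gives > 100000 nM in this assay, a value that is a limit of the assay and not a number (the limit of > 100000 nM in this assay, at which 1 of the 2 values shown sits).

Within the data shown here, compound 1 thus carries the only actual number here; the other entry is a limit. Compound 3 `CCCn1c(=O)c2nc(C(C)(C)C)[nH]c2n(CCC)c1=O` has not yet been measured. It differs from compound 1 by a group of 4 heavy atoms (4 carbon; no ring) in place of a group of 7 heavy atoms (7 carbon; 2 five-membered non-aromatic rings of carbon only), on an aromatic carbon, in words: a group of 4 heavy atoms (4 carbon; no ring) in place of a group of 7 heavy atoms (7 carbon; 2 five-membered non-aromatic rings of carbon only), on an aromatic carbon. Among the measured compounds shown here, no measured pair differs in just one place, so the size of such a swap has not been seen directly. The tert-butyl group is expected to weaken binding, by an 8.8-fold higher number from compound 1 to compound 3 (0.95 log units; beyond the scatter), beyond the usual scatter. Compound 3 is therefore estimated at 30 nM in this assay, with a likely range from 5 nM to 200 nM.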

Compound 3, inhibition constant: 31 nM
Compound 3: middle estimate off by 1.0-fold (0.01 log units), on the low side; the measured number falls inside the stated range.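

Replacing the group with two five-membered carbon rings by tert-butyl on this aromatic carbon gives a 9.1-fold higher number from compound 1 to compound 3 (0.96 log units; beyond the scatter) in this assay. Binding therefore weakens beyond the scatter when both rings and the double bond go, yet compound 3 still gives an actual number and not a limit. Nothing measured here accounts for the size of this step. The compounds shown leave open how an amine, a carboxylic acid or a longer chain would fare on this carbon. They also do not separate the share of the rings from that of the double bond.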